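The source may report more compounds than this note shows. Statements on the series, on what has been measured and on what is new or still open speak of the compounds shown alone.

Working notes on the series. In an assay on HEK293 cells for inhibition of acid ceramidase (Rattus norvegicus), read by LC-MS, with a stated time of 30 min (a higher number here means a weaker inhibitor, a lower number a stronger inhibitor), compound 1 `CCCCCCNC(=O)n1cc(F)c(=O)n(CC2CC2)c1=O` gives 61 nM, and compound 2 `CCCCCCNC(=O)n1cc(F)c(=O)n(C(=O)OC)c1=O` gives 7 nM. Among the compounds with values here, the one step between them, an 8.7-fold lower number from compound 1 to compound 2 (0.94 log units; beyond the scatter), is the only measured step in the set; compound 2 therefore holds the lowest of the two numbers, with compound 1 as its nearest neighbour at the higher end. Compound 3 `CCCCCCNC(=O)n1cc(F)c(=O)n(C(=O)OCC)c1=O` is not yet measured in this assay. It differs from compound 2 by methyl in place of hydrogen on a saturated chain carbon bound to an oxygen next to a carbonyl group, so that methoxycarbonyl becomes ethoxycarbonyl. Within the data shown here, no measured step involves a change of this kind: the step from compound 1 to compound 2 exchanges a whole group rather than lengthening a chain, so it gives no direct guide. The step of no change at the digits printed from compound 2 to compound 3 (within the scatter) is expected to stay within the scatter. For compound 3 the estimate in this assay is 7 nM, with a range from 3 nM to 18 nM.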

Compound 3, half-maximal inhibitory concentration: 12 nM
Estimate against measurement, compound 3: 1.7-fold (0.23 log units) below; the range from low to high includes it.
By their numbers in this assay, from the lowest: compounds 2 and 3 (each within the scatter of the next); then compound 1.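

In this assay, methyl in place of hydrogen on a saturated chain carbon bound to an oxygen next to a carbonyl group gives a 1.7-fold higher number from compound 2 to compound 3 (0.23 log units; within the scatter) and so leaves the number within the scatter, which means that methoxycarbonyl and ethoxycarbonyl cannot be told apart here. The gain over cyclopropylmethyl on the aromatic nitrogen no longer rests on methoxycarbonyl alone: ethoxycarbonyl also gives a lower number, with a 5.1-fold lower number from compound 1 to compound 3 (0.71 log units; beyond the scatter) beyond the scatter. Nothing measured here bears on the reason for either step.

The compounds shown leave open how far this tolerance extends, whether to a longer chain such as butoxycarbonyl or to a branched tert-butoxycarbonyl group. They also leave open whether a carboxamide in place of the carbamate-type ester on this nitrogen would fall in the same range.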